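The source may report more compounds than this note shows. Statements on the series, on what has been measured and on what is new or still open speak of the compounds shown alone.

Measured so far in a functional assay on HL-60 cells (Homo sapiens) for antiproliferative activity, with a stated time of 24 h; on this read-out higher numbers stand for weaker inhibition and lower numbers for stronger inhibition:

compound 1 `NC(=O)c1c(NC(=O)c2ccccc2Cl)sc2c1CCN(C(=S)Nc1cccc3ccccc13)C2`: 13400 nM
compound 2 `NC(=O)c1c(NC(=O)c2ccccc2Cl)sc2c1CCN(C(=S)Nc1ccc(C(F)(F)F)cc1)C2`: 7590 nM
compound 3 `NC(=O)c1c(NC(=O)c2ccccc2Cl)sc2c1CCN(C(=O)Nc1c(Cl)cccc1Cl)C2`: 17700 nM

Compound 3 gives the highest of the three numbers; its gap to compound 1 lies within the scatter, while its gap to compound 2 lies beyond it. Among the measured compounds shown here, the only step between compounds differing in one place, a 1.8-fold lower number from compound 1 to compound 2 (0.25 log units; within the scatter), shows that exchanging one aromatic group on that nitrogen for another moved the number little.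

Compound 4 `NC(=O)c1c(NC(=O)c2ccccc2Cl)sc2c1CCN(C(=S)Nc1cccnc1)C2` arises from compound 3 by a group of 9 heavy atoms (6 carbon, 2 nitrogen, 1 sulfur; one six-membered aromatic ring with 1 hetero atom) in place of a group of 11 heavy atoms (7 carbon, 1 nitrogen, 1 oxygen, 2 chlorine; one six-membered aromatic ring of carbon only), on an amine nitrogen in a ring. This change touches two things at once: the aromatic ring loses both chlorines and gains a ring nitrogen, and the group bearing it holds a sulfur where compound 3 holds an oxygen, as the groups of compound 1 and compound 2 do. For the measured compounds named here, no measured step isolates either part. Going by the values given here, the single relevant step, from compound 1 to compound 2, stayed within the scatter, and all three numbers cluster within a narrow band, so for compound 4 no step beyond the scatter in this assay is expected. Compound 4 is therefore estimated at 12000 nM, between 4000 nM and 40000 nM, an expected step of a 1.5-fold lower number from compound 3 to compound 4 (0.17 log units; within the scatter).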

Compound 4, half-maximal inhibitory concentration: 33900 nM
Compound 4: middle estimate off by 2.8-fold (0.45 log units), on the low side, within the range that was stated.
By their numbers in this assay, from the lowest: compounds 2, 1, 3 and 4 (each within the scatter of the next, the first and the last beyond it).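

In this assay, pyridin-3-yl in place of 4-(trifluoromethyl)phenyl on an amide-type nitrogen gives a 4.5-fold higher number from compound 2 to compound 4 (0.65 log units; beyond the scatter) and pyridin-3-yl in place of naphthalen-1-yl gives a 2.5-fold higher number from compound 1 to compound 4 (0.40 log units; beyond the scatter), so the aromatic group at this nitrogen can shift the number, modestly, although the exchange seen earlier, a 1.8-fold lower number from compound 1 to compound 2 (0.25 log units; within the scatter), did not show this. The exchange of the (2,6-dichlorophenyl)carbamoyl group on the amine nitrogen in a ring for the group bearing pyridin-3-yl gives a 1.9-fold higher number from compound 3 to compound 4 (0.28 log units; within the scatter) and so does not set compound 4 apart from compound 3, while changing the aromatic ring and the sulfur together, which leaves neither part separately readable. Nothing measured alongside these numbers accounts for the steps.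

The compounds shown leave open whether the higher numbers with pyridin-3-yl follow from the ring nitrogen itself, a question that a plain phenyl group on the same sulfur-bearing group would address. They also leave open how the sulfur and oxygen forms compare with one aromatic group held fixed, and whether a cyclohexyl group on that nitrogen would stay in the same range.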